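The compounds below may be only part of what the source reports. "The series", "measured", "known", "first", "only" and "open" are said of these compounds alone.

Values in a functional assay on U-937 cells (Homo sapiens) for cytotoxicity, read by MTT assay, with a stated time of 48 h; a higher number here means a weaker inhibitor, a lower number a stronger inhibitor:
- compound 1 `Fc1cccc(-c2nc(Nc3ccccc3)c3cc(F)ccc3n2)c1`: 45500 nM
- compound 2 `COc1ccccc1Nc1nc(-c2cccc(F)c2)nc2ccc(F)cc12`: > 50000 nM, a limit of the assay, not a number
- compound 3 `Oc1ccccc1Nc1nc(-c2cccc(F)c2)nc2ccc(F)cc12`: 46300 nM

The two numbers do not separate: a 1.0-fold higher number from compound 1 to compound 3 (0.01 log units; within the scatter). Among the compounds with values here, compound 3 thus stands level with the only other numeric value.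

The next change gives compound 4 `Cc1ccc(Nc2nc(-c3cccc(F)c3)nc3ccc(F)cc23)cc1`: 4-methylphenyl in place of 2-hydroxyphenyl on a nitrogen on an aromatic ring. In words, 4-methylphenyl replaces 2-hydroxyphenyl on a nitrogen on an aromatic ring.

Hydroxy gave the step above. Methoxy gave an at least 1.0-fold higher number from compound 1 to compound 2 (0.04 log units; that floor lies within the scatter), and removing its methyl gave an at least 1.0-fold lower number from compound 2 to compound 3 (0.03 log units; that floor lies within the scatter); both floors lie within the scatter. Within the data shown here, no measured step covers 4-methylphenyl.

Expected here is no shift beyond the scatter: a 1.2-fold lower number from compound 3 to compound 4 (0.09 log units; within the scatter).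

The estimate for compound 4 is 38000 nM, with an expected range of 15000 nM to 50000 nM.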

Compound 4, half-maximal inhibitory concentration: > 50000 nM
Compound 4: no number, only a limit; the forecaster's own chance of this, stated with the estimate: 40%; middle value at least 1.3-fold (0.11 log units) from the limit.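

4-methylphenyl carries no hydrogen-bond donor or acceptor, unlike 2-hydroxyphenyl, and the change gives an at least 1.0-fold higher number from compound 3 to compound 4 (0.03 log units; that floor lies within the scatter). Methyl in place of hydrogen on an aromatic carbon gives an at least 1.0-fold higher number from compound 1 to compound 4 (0.04 log units; that floor lies within the scatter), while the step from compound 2 to compound 4 cannot be read. A carbon-only group thus joins hydroxy and methoxy: no readable step on this nitrogen's aryl group passes the scatter, and the series sits at its ceiling: the limit of > 50000 nM in this assay, at which 2 of the 4 values shown sit.

As far as these compounds go, whether an amine or a carboxylic acid on this phenyl ring would give a number clearly under that limit stays open. From the compounds shown here alone, how far compound 2 and compound 4 lie past the limit also stays open.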